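The compounds below may be only part of what the source reports. "The series", "measured", "known", "first", "only" and "open" are said of these compounds alone.

In a functional assay on HEK293 cells (Homo sapiens) for cytotoxicity (on this read-out higher numbers stand for lower toxicity in this test and lower numbers for higher toxicity in this test), compound 1 (`COc1ccc([C@H]2CC(=O)N(c3cccc(N(C)C)c3)C2)cc1OC1CCCC1`) gives > 10000 nM as a limit and not a number. Compound 2 (`COc1ccc([C@H]2CC(=O)N(c3ccccc3N)C2)cc1OC1CCCC1`) gives > 10000 nM as a limit too. Compound 3 (`COc1ccc([C@H]2CC(=O)N(c3ccc(C(F)(F)F)cc3)C2)cc1OC1CCCC1`) gives > 10000 nM as a limit as well. Compound 3 therefore has no number of its own. It stands with the other two at the limit of > 10000 nM in this assay, at which 3 of the 3 values shown sit, and cannot be ranked against them.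

Compound 4 (`COc1ccc([C@H]2CC(=O)N(c3ccc(S(C)(=O)=O)cc3)C2)cc1OC1CCCC1`) brings one change (methylsulfonyl in place of trifluoromethyl on an aromatic carbon) with methylsulfonyl in place of trifluoromethyl on an aromatic carbon, para to a large group.

The measured steps that bear on this change all swap the group on the amide-type nitrogen in a ring. They are a step that the two limits leave unreadable from compound 1 to compound 3 and a step that the two limits leave unreadable from compound 2 to compound 3 and also a step that the two limits leave unreadable from compound 1 to compound 2 and none of them has a readable size. Nothing in them points to a size or a direction for the new change. The expected outcome is therefore a step that the limit leaves unreadable from compound 3 to compound 4 and no step beyond the scatter is expected in either direction. The expected value for compound 4 is 15000 nM with an estimated range from 7000 nM to 40000 nM and this assay may well report only a limit again.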

Compound 4, half-maximal cytotoxic concentration: > 10000 nM
Compound 4: only a limit was reported; the forecaster's own chance of this, stated with the estimate: 88%; the middle value does not contradict the limit.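

Compound 4 again gives only a limit in this assay, so its steps from compound 1, compound 2 and compound 3 cannot be read: the limit of > 10000 nM in this assay, at which 4 of the 4 values shown sit.

The compounds shown leave open whether the group on the amide-type nitrogen in a ring affects the result in this assay at all, as none of the four has a number of its own.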